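Fluoro Substitution on a Bis-indolyl Oxindole Series

This account rests on a few compounds, and the source may have more. Where it says the series, first, only, none or still open, it means among the compounds named here.

The measured compounds are:
compound 1, `COc1ccc2[nH]cc(C3(c4c[nH]c5ccc(OC)cc45)C(=O)Nc4ccccc43)c2c1`, 3900 nM;
compound 2, `O=C1Nc2ccccc2C1(c1c[nH]c2ccc(Cl)cc12)c1c[nH]c2ccc(Cl)cc12`, 9400 nM;
compound 3, `COc1ccc2[nH]cc(C3(c4c[nH]c5ccc(OC)cc45)C(=O)Nc4ccc(F)cc43)c2c1`, 7000 nM.

All three were tested in a functional assay on SK-N-SH cells (Homo sapiens) for cytotoxicity, read by MTT assay, with a stated time of 48 h; on this read-out lower numbers stand for stronger inhibition and higher numbers for weaker inhibition. Compound 1 gives 3900 nM in this assay, and compound 3 gives 7000 nM. The two differ by fluoro in place of hydrogen on an aromatic carbon, and the step is a 1.8-fold higher number from compound 1 to compound 3 (0.25 log units; within the scatter). Compound 2 carries chloro groups in place of the methoxy groups of compound 1, and compound 2 gives 9400 nM in this assay; the difference between the two cores is not broken down here.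

Compound 4, `O=C1Nc2ccc(F)cc2C1(c1c[nH]c2ccc(Cl)cc12)c1c[nH]c2ccc(Cl)cc12`, has not yet been measured. It differs from compound 2 by fluoro in place of hydrogen on an aromatic carbon, which is the same change as that from compound 1 to compound 3. Given that the earlier step was a 1.8-fold higher number from compound 1 to compound 3 (0.25 log units; within the scatter), a similar, modest step is expected here, with the estimated size a 1.5-fold higher number from compound 2 to compound 4 (0.17 log units; within the scatter). Compound 4 is therefore expected to give about 14000 nM in this assay, with a likely range from 7000 nM to 30000 nM.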

Compound 4, half-maximal inhibitory concentration: 8500 nM
Compound 4: middle estimate off by 1.6-fold (0.22 log units), on the high side; the measured number falls inside the stated range.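

In this assay, the step for fluoro in place of hydrogen on an aromatic carbon on the core of compound 2 is a 1.1-fold lower number from compound 2 to compound 4 (0.04 log units; within the scatter). Set beside the same change on the core of compound 1, the two steps do not differ by more than repeated measurements allow: the same change on two cores in this assay, a 1.8-fold higher number (0.25 log units; within the scatter) from compound 1 to compound 3 and a 1.1-fold lower number (0.04 log units; within the scatter) from compound 2 to compound 4, 2.0-fold (0.30 log units) apart, within the scatter of two such steps. The change therefore shows no sign of behaving differently on these two cores, but each step lies within the scatter on its own, so neither shows that fluoro has any real effect here, and two cores cannot show what would happen on a third.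

The compounds shown leave open whether another group on that same aromatic carbon, such as a nitrile or an amine, would give a step beyond the scatter. They also leave open what replacing the amide hydrogen with a methyl group or a longer chain would do to the numbers.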